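The source may report more compounds than this note shows. Statements on the series, on what has been measured and on what is new or still open speak of the compounds shown alone.

Three compounds have so far been measured in a functional assay on MCF7 cells (Homo sapiens) for inhibition, read by MTT assay, with a stated time of 72 h; a lower number here means a stronger inhibitor, a higher number a weaker inhibitor:

Compound 1, `Cc1ccc(NC(=O)c2ccc(/N=N\c3c[nH]c4ccccc34)cc2)c(C)c1`, gives 87000 nM.
Compound 2, `O=C(Nc1cccc(Cl)c1)c1ccc(/N=N\c2c[nH]c3ccccc23)cc1`, gives 82700 nM.
Compound 3, `O=C(Nc1ccc([N+](=O)[O-])cc1)c1ccc(/N=N\c2c[nH]c3ccccc23)cc1`, gives 54500 nM.

All three share the same core and differ only in the group on the amide-type nitrogen. Compound 2 sits between the other two on the numbers, but the steps of a 1.1-fold lower number from compound 1 to compound 2 (0.02 log units; within the scatter) and a 1.5-fold lower number from compound 2 to compound 3 (0.18 log units; within the scatter) both lie within the scatter, so the three compounds cannot be separated by these values.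

The next compound, compound 4, `O=C(Nc1cccc([N+](=O)[O-])c1)c1ccc(/N=N\c2c[nH]c3ccccc23)cc1`, differs from compound 2 in one place: nitro in place of chloro on an aromatic carbon. Cut one bond further out, this reads 3-chlorophenyl to 3-nitrophenyl.

Within the data shown here, two measured steps bear on this change. The step of a 1.5-fold lower number from compound 2 to compound 3 (0.18 log units; within the scatter) also exchanges chloro for nitro on this ring, and the step of a 1.6-fold lower number from compound 1 to compound 3 (0.20 log units; within the scatter) brings in a nitro group as well; neither moves the number beyond the scatter. Compound 4 is therefore expected to show no step beyond the scatter, which means an estimated change of a 1.2-fold lower number from compound 2 to compound 4 (0.07 log units; within the scatter). For compound 4 the estimate in this assay is 70000 nM, with a range from 30000 nM to 160000 nM.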

Compound 4, half-maximal inhibitory concentration: 51900 nM
For compound 4 the middle estimate is 1.3-fold (0.13 log units) above the measured one, within the range that was stated.
By their numbers in this assay, from the lowest: compounds 4, 3, 2 and 1 (each within the scatter of the next).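

In this assay the exchange of chloro for nitro can now be read with the place on the ring held fixed: on an aromatic carbon meta to a large group, it gives a 1.6-fold lower number from compound 2 to compound 4 (0.20 log units; within the scatter) and so does not separate these two compounds. Moving the nitro group is a new kind of change, and going from 4-nitrophenyl to 3-nitrophenyl gives a 1.1-fold lower number from compound 3 to compound 4 (0.02 log units; within the scatter) so, for this pair, the place of the nitro group makes no difference that can be read. Replacing 2,4-dimethylphenyl with 3-nitrophenyl gives a 1.7-fold lower number from compound 1 to compound 4 (0.22 log units; within the scatter) and this step also stays within the scatter, so the four compounds still cannot be put in a reliable order.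

Going by these compounds, it remains open whether an amine or a carboxylic acid on this ring, or a longer chain in place of the aromatic ring on the amide-type nitrogen, would move the number beyond the scatter. Nothing measured here offers an explanation for these small steps.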